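Heteroaryl amides on a shared phthalimide-bearing core

A few compounds are considered here, and "the series" means these few. Any claim that something is new, unique, unknown or untested is made for them only; others in the source may bear on it.

Compound 1 `O=C(Nc1ccc(Cl)cc1CN1C(=O)c2ccccc2C1=O)c1ccccc1[N+](=O)[O-]`: 5700 nM
Compound 2 `O=C(Nc1ccc(Cl)cc1CN1C(=O)c2ccccc2C1=O)c1cccnc1`: 35000 nM
Compound 3 `O=C(Nc1ccc(Cl)cc1CN1C(=O)c2ccccc2C1=O)c1ccccc1C(F)(F)F`: 5700 nM

All three compounds share one core and differ only in the group attached to the carbonyl carbon of the amide. In an assay on CHO cells for positive allosteric modulation of metabotropic glutamate receptor 5 (Homo sapiens), read by FLIPR (a higher number here means that more compound is needed for the effect, a lower number that less compound is needed), compound 3 stands level with compound 1 at the digits shown, and together they give the lowest numbers of the three; the step of no change at the digits printed from compound 1 to compound 3 (within the scatter) lies within the scatter. Compound 2, which carries pyridin-3-yl, is the outlier: the step of a 6.1-fold lower number from compound 2 to compound 3 (0.79 log units; beyond the scatter) is beyond the scatter, as is a 6.1-fold higher number from compound 1 to compound 2 (0.79 log units; beyond the scatter).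

Compound 4 `O=C(Nc1ccc(Cl)cc1CN1C(=O)c2ccccc2C1=O)c1ncccn1` carries the change (pyrimidin-2-yl in place of 2-(trifluoromethyl)phenyl on a carbonyl carbon). This removes the substituted carbon-only ring and puts in a small ring with two nitrogens, much as compound 2 did with pyridin-3-yl. The step of a 6.1-fold lower number from compound 2 to compound 3 (0.79 log units; beyond the scatter) is the one that bears most directly on this change, and it suggests that replacing a substituted phenyl by a heteroaryl ring on this carbonyl costs potency. Compound 4 is therefore expected to show a step of about a 5.3-fold higher number from compound 3 to compound 4 (0.72 log units; beyond the scatter), with a weaker value near that of compound 2. The estimate for compound 4 in this assay is 30000 nM, ranging from 10000 nM to 100000 nM.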

Compound 4, half-maximal effective concentration: 2100 nM
The estimate for compound 4 lay 14-fold (1.15 log units) above the measured number, outside the stated range (below it).
By their numbers in this assay, from the lowest: compound 4; then compounds 1 and 3 (each within the scatter of the next); then compound 2.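

In this assay, a heteroaryl ring on this carbonyl carbon does not have to cost potency: pyrimidin-2-yl gives a 2.7-fold lower number from compound 3 to compound 4 (0.43 log units; beyond the scatter) and a 2.7-fold lower number from compound 1 to compound 4 (0.43 log units; beyond the scatter) in a second comparison with a substituted phenyl. Among the two heteroaryl rings shown, the choice of ring matters far more, with a 17-fold lower number from compound 2 to compound 4 (1.22 log units; beyond the scatter) on changing pyridin-3-yl to pyrimidin-2-yl, so compound 2 and compound 4 point in opposite directions relative to the substituted phenyl compounds. Nothing measured here accounts for this difference between the two rings.

The compounds shown leave open whether a plain phenyl, pyridin-2-yl or pyrazin-2-yl group on this carbonyl carbon would fall nearer compound 4 or compound 2. They also leave open how a pyrimidin-2-yl ring carrying an amine or a carboxylic acid would behave.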